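Chlorinated Benzoic Acid in Place of a Methyl Benzoic Acid

The source may hold more compounds than are shown below. What is called first, only, known or untested is meant among the compounds shown, and "the series" means these compounds.

Compound 1, `COc1ccc(C(=O)O)cc1O[C@@H](C)COc1ccc(C(=O)CC(C)(C)C)c(O)c1C`: 2210 nM
Compound 2, `Cc1ccc(OC[C@H](C)COc2ccc(C(=O)CC(C)(C)C)c(O)c2C)cc1C(=O)O`: > 10000 nM

In an assay for positive allosteric modulation of metabotropic glutamate receptor 3 (Rattus norvegicus) (a higher number here means that more compound is needed for the effect, a lower number that less compound is needed), compound 1 gives 2210 nM. Compound 2 gives only > 10000 nM, which is a limit of the assay rather than a number; compound 2 stands at the limit of > 10000 nM in this assay, at which 1 of the 2 values shown sits. Compound 3, `Cc1c(OC[C@@H](C)COc2ccc(C(=O)O)c(Cl)c2)ccc(C(=O)CC(C)(C)C)c1O`, differs from compound 2 by 4-carboxy-3-chlorophenyl in place of 3-carboxy-4-methylphenyl on an oxygen on a saturated carbon. Among the measured compounds shown here, no measured pair shows a change of this kind, so no step size can be read from the data. The step from compound 2 to compound 3 in this assay is expected to be an at least 2.8-fold lower number from compound 2 to compound 3 (0.45 log units; beyond the scatter), a gain beyond the scatter. Compound 3 is estimated at 3500 nM, with a range from 900 nM to 14000 nM.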

Compound 3, half-maximal effective concentration: 860 nM
Estimate against measurement, compound 3: 4.1-fold (0.61 log units) above, and the stated range ends above it.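

On an oxygen on a saturated carbon, the aryl group matters a great deal: in this assay, 4-carboxy-3-chlorophenyl in place of 3-carboxy-4-methylphenyl gives an at least 11-fold lower number from compound 2 to compound 3 (1.06 log units; beyond the scatter) and brings a measurable value. On these data alone, the true size of this step remains unknown, since compound 2 gives a limit of the assay and not a number: the limit of > 10000 nM in this assay, at which 1 of the 3 values shown sits. Among the compounds shown here, the single swap changes both the substituent and the numbered place of the carboxy group, so the two contributions cannot be separated. As far as these compounds go, a 4-carboxy-3-methylphenyl group would bear on that question, and how a tetrazole would compare with the carboxylic acid stays open.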